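Tertiary amide variation at the carbonyl of compound 1

A few compounds are considered here, and "the series" means these few. Any claim that something is new, unique, unknown or untested is made for them only; others in the source may bear on it.

Compound 1 `COc1cc2c(cc1OC)C(CC(N)=O)CC2` gives 26.7% in a functional assay on the whole organism (strain Wistar) for inhibition, with Rattus norvegicus as the target, read by paw edema, with stated times of 60 min and 24 h, at a dose of 100 mg/kg by the oral route (a higher number here means more inhibition at the dose given (going by the name of the read-out), a lower number less inhibition), the second highest of three numbers. Compound 2 `COc1cc2c(cc1OC)C(CC(=O)N(C)C)CC2` gives 23.3% and compound 3 `CCCCNC(=O)CC1CCc2cc(OC)c(OC)cc21` gives 36.7%. Within the data shown here, the steps run a number 3.4 percentage points lower from compound 1 to compound 2 (within the scatter) and a number 10 percentage points higher from compound 1 to compound 3 (within the scatter), while a number 13.4 percentage points higher from compound 2 to compound 3 (beyond the scatter) is the only step beyond the scatter. Compound 4 `COc1cc2c(cc1OC)C(CC(=O)N1CCCC1)CC2` differs from compound 1 by pyrrolidin-1-yl in place of amino on a carbonyl carbon. The step that bears most on it is the one to the other tertiary amide, a number 3.4 percentage points lower from compound 1 to compound 2 (within the scatter), which stayed within the scatter; compound 4, like compound 2, has no hydrogen left on the amide-type nitrogen, whereas compound 3 keeps one. No step beyond the scatter is therefore expected, a number 1.7 percentage points lower from compound 1 to compound 4 (within the scatter). For compound 4 the estimate is 25%, within 12% to 38%.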

Compound 4, a percentage reported as inhibition, in the whole organism at one dose (the size of the read-out at that dose, not a potency): 33.3%
Compound 4: the middle estimate sits 8.3 percentage points below what was measured; the measured number falls inside the stated range.
By their numbers in this assay, from the lowest: compounds 2, 1, 4 and 3 (each within the scatter of the next, the first and the last beyond it).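

In this assay, the pyrrolidin-1-yl amide lies within the scatter of all three other amides: a number 6.6 percentage points higher from compound 1 to compound 4 (within the scatter), a number 3.4 percentage points lower from compound 3 to compound 4 (within the scatter) and a number 10 percentage points higher from compound 2 to compound 4 (within the scatter). Compound 4 has no hydrogen on the amide-type nitrogen, yet it does not separate from compound 3, which keeps one, so the loss of that hydrogen alone does not track the one gap beyond the scatter, between compound 2 and compound 3. No measurement available explains this result. Still open, as far as these compounds go, is whether piperidin-1-yl, morpholin-4-yl or a chain longer than butyl at this carbonyl would move the number beyond the scatter from compound 1.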